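The compounds below may be only part of what the source reports. "The series", "measured", "known", "first", "only" and "open" are said of these compounds alone.

Working notes on the series in a functional assay on CCRF-CEM cells (Homo sapiens) for inhibition, read by MTT assay, with a stated time of 72 h; on this read-out lower numbers stand for stronger inhibition and higher numbers for weaker inhibition. For the measured compounds named here, compound 1 (`COc1cc(NC(C)CCCNC(=O)NNC(=O)Nc2ccc(Br)cc2)c2ncccc2c1`) gives 110000 nM, the highest of the three numbers so far. Compound 2 (`COc1cc(NC(C)CCCNC(=O)Nc2cccc(O)c2)c2ncccc2c1`) gives 32000 nM, and compound 3 (`COc1cc(NC(C)CCCNC(=O)Nc2cc(C(F)(F)F)cc(C(F)(F)F)c2)c2ncccc2c1`) gives 4100 nM, the number furthest from that of compound 1.

The next compound is compound 4 (`COc1cc(NC(C)CCCNC(=O)NNC(=O)Nc2ccc(O)cc2)c2ncccc2c1`), which differs from compound 1 in one place: hydroxy in place of bromo on an aromatic carbon. In words, this is hydroxy in place of bromo on an aromatic carbon, para to a large group.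

Going by the values given here, only one measured step bears on this change: a 3.4-fold lower number from compound 1 to compound 2 (0.54 log units; beyond the scatter). That step is modest, and it replaces the whole ((4-bromophenyl)carbamoyl)amino group, so it does not isolate the exchange of bromo for hydroxy. Among the compounds with values here, it shows only that a compound carrying a 3-hydroxyphenyl group, compound 2 at 32000 nM, reads lower than compound 1. Compound 3 offers no single-place comparison. In this assay, a smaller step than the measured one is therefore expected, leaning towards a lower number and possibly not beyond the scatter. The estimated change is a 1.6-fold lower number from compound 1 to compound 4 (0.20 log units; within the scatter). For compound 4 the expected value is 70000 nM, with an estimated range from 25000 nM to 200000 nM.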

Compound 4, half-maximal inhibitory concentration: 111000 nM
Compound 4: the middle estimate sits 1.6-fold (0.20 log units) below what was measured; the measured number falls inside the stated range.
By their numbers in this assay, from the lowest: compound 3; then compound 2; then compounds 1 and 4 (each within the scatter of the next).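

In this assay, the exchange of bromo for hydroxy on an aromatic carbon, para to a large group, gives a 1.0-fold higher number from compound 1 to compound 4 (0.00 log units; within the scatter), so this position shows no response to this change, even though the hydroxy brings a hydrogen-bond donor and a hydrogen-bond acceptor that the bromo lacks. The step of a 3.5-fold higher number from compound 2 to compound 4 (0.54 log units; beyond the scatter), with ((4-hydroxyphenyl)carbamoyl)amino in place of 3-hydroxyphenyl, lies beyond the scatter and is modest, so a hydroxy-bearing aromatic ring on both sides does not bring the two numbers together, and the earlier step of a 3.4-fold lower number from compound 1 to compound 2 (0.54 log units; beyond the scatter) cannot be credited to the loss of bromo alone. Nothing measured here bears on the reason for either result.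

Going by these compounds, it remains open whether the flat response holds only for bromo and hydroxy, or whether an amine, a carboxylic acid or a methoxy at the same place would also leave the number unchanged. Also open, on these data alone, is whether the same exchange would read alike on the shorter urea of compound 2 or compound 3, where the numbers are lower and any change might be easier to see.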